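Swapping Methyl for Chloro on Compound 1

This account rests on a few compounds, and the source may have more. Where it says the series, first, only, none or still open, it means among the compounds named here.

Measured in an ADME assay on CHO cells (Cricetulus griseus) for inhibition, read by MTT assay; a higher number here means a weaker inhibitor, a lower number a stronger inhibitor:
- compound 1 `CCNCc1cc(C)cc(Nc2nc3ccccc3n2Cc2ccc(C(F)(F)F)cc2)c1O`: 18800 nM
- compound 2 `CC(C)(C)NCc1cc(C(C)(C)C)cc(Nc2nc3ccccc3[nH]2)c1O`: 30500 nM

These two values lie within the usual scatter of each other, so compound 1 cannot be separated from compound 2 on these numbers. Compound 3 `CCNCc1cc(Cl)cc(Nc2nc3ccccc3n2Cc2ccc(C(F)(F)F)cc2)c1O` keeps the core of compound 1 with one change: chloro in place of methyl on an aromatic carbon, para to a hydroxy group. For the measured compounds named here, no measured pair shows a single change, so the data offer no direct guide. The estimated step is a 1.2-fold lower number from compound 1 to compound 3 (0.07 log units; within the scatter), expected to stay within the scatter. The estimate for compound 3 is 16000 nM, with an expected range of 7000 nM to 36000 nM.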

Compound 3, half-maximal inhibitory concentration in the CHO assay: 33800 nM
Beside the measured number, compound 3's estimate is 2.1-fold (0.32 log units) below it; measured number inside the range.
By their numbers in the CHO assay, from the lowest: compounds 1, 2 and 3 (each within the scatter of the next).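

In the CHO assay, chloro in place of methyl on this aromatic carbon, para to a hydroxy group, gives a 1.8-fold higher number from compound 1 to compound 3 (0.25 log units; within the scatter), so this pair shows no separable effect on inhibition. In a physicochemical assay for solubility, read by HPLC, measured as kinetic solubility, with a stated time of 24 h, at pH 6.5 (a higher number here means a more soluble compound, a lower number a less soluble compound), compound 1 gives 35000 nM and compound 3 gives 12000 nM. This is the only single-change pair shown, and in the physicochemical assay the same swap does separate the two compounds, with chloro giving the less soluble compound: the measured solubility of compound 1, 35000 nM, and of compound 3, 12000 nM, a 2.9-fold lower number (0.46 log units; beyond the scatter)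

Still open, going by these compounds, is how a methoxy group, a nitrile or an amine at this position would behave in the CHO assay and the physicochemical assay. On these data alone, whether the solubility step carries over to other cores is also open.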